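A hydroxyphenyl hydrazone swapped for a methoxyphenyl one

The source may report more compounds than this note shows. Statements on the series, on what has been measured and on what is new or still open speak of the compounds shown alone.

Compound 1 `Cc1c(C(=O)N/N=C\c2cc(F)ccc2O)oc2cccc(O)c12` is a hydrazone built on a shared core, and in a functional assay on PC-3 cells (Homo sapiens) for inhibition (on this read-out higher numbers stand for weaker inhibition and lower numbers for stronger inhibition), compound 1 gives 3170 nM. That is the lowest of the two numbers measured in this assay. Compound 3 `Cc1ccc(O)c(/C=N\NC(=O)c2oc3cccc(O)c3c2C)c1` gives 7350 nM in this assay, and the step of a 2.3-fold higher number from compound 1 to compound 3 (0.37 log units; beyond the scatter) is beyond the scatter. Compound 2 `Cc1c(C(=O)N/N=C\c2ccccn2)oc2cccc(O)c12` reaches only a limit of this assay, >= 40000 nM (the limit of >= 40000 nM in this assay, at which 1 of the 3 values shown sits). The step of an at least 12-fold higher number from compound 1 to compound 2 (1.10 log units; beyond the scatter) shows that losing the 5-fluoro-2-hydroxyphenyl ring for a pyridin-2-yl costs much, and an at least 5.4-fold lower number from compound 2 to compound 3 (0.73 log units; beyond the scatter) shows the hydroxyphenyl ring regained together with a methyl recovers part of it.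

Compound 4 `COc1cccc(/C=N\NC(=O)c2oc3cccc(O)c3c2C)c1` has not been measured. It differs from compound 1 by 3-methoxyphenyl in place of 5-fluoro-2-hydroxyphenyl on a carbon with a double bond to nitrogen. The change removes the hydroxy of the leaving group, as the step from compound 1 to compound 2 did, so a clear move toward weaker inhibition is expected, though smaller than that large step since an aromatic carbon ring remains. For compound 4 the step of a 4.7-fold higher number from compound 1 to compound 4 (0.68 log units; beyond the scatter) is expected in this assay. Compound 4 is estimated at 15000 nM in this assay, within 5000 nM to 40000 nM.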

Compound 4, half-maximal inhibitory concentration: >= 40000 nM
Compound 4 ended at the assay's limit (the forecaster's own chance of this, stated with the estimate: 30%); at least 2.6-fold (0.42 log units) between middle value and limit.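

For compound 4 the result in this assay is a limit of the assay and not a number: the limit of >= 40000 nM in this assay, at which 2 of the 4 values shown sit. Keeping a carbon aromatic ring at this place therefore does not retain the inhibition seen with compounds 1 and 3, as shown by an at least 12-fold higher number from compound 1 to compound 4 (1.10 log units; beyond the scatter) and by an at least 5.4-fold higher number from compound 3 to compound 4 (0.73 log units; beyond the scatter). Among these four compounds, the two with a 2-hydroxyphenyl-type ring give numbers, while pyridin-2-yl and 3-methoxyphenyl both end at the limit, so the step between those two cannot be read.

The change to compound 4 removes the hydroxy and the fluoro and adds the methoxy all at once, so the share of each remains unresolved. As far as these compounds go, how an aminophenyl or an unsubstituted phenyl ring would behave at this place also remains open.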